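Swapping methoxy for chloro on a hydroxamic acid series

The source may hold more compounds than are shown below. What is called first, only, known or untested is meant among the compounds shown, and "the series" means these compounds.

Of the compounds shown here, three have been measured so far. Compound 1, `COc1ccc(C(=O)c2ccc3c(ccn3Cc3ccc(C(=O)NO)cc3)c2)cc1OC`, gives 756 nM in an assay on isolated protein for inhibition of histone deacetylase 8 (Homo sapiens); a higher number here means a weaker inhibitor, a lower number a stronger inhibitor. Compound 2, `O=C(NO)c1ccc(Cn2ccc3cc(C(=O)c4ccc(F)cc4)ccc32)cc1`, gives 1240 nM in this assay. Compound 3, `COc1ccc(C(=O)c2ccc3c(ccn3Cc3ccc(C(=O)NO)cc3)c2)cc1`, gives 646 nM in this assay.

Compound 3 has the lowest number of the three, but its distance to compound 1 is small and even its distance to compound 2 stays within the scatter: a 1.9-fold lower number from compound 2 to compound 3 (0.28 log units; within the scatter). The three compounds share one core and differ only in the ring attached to the carbonyl: 3,4-dimethoxyphenyl in compound 1, 4-fluorophenyl in compound 2, 4-methoxyphenyl in compound 3. The step from compound 1 to compound 2 was a 1.6-fold higher number from compound 1 to compound 2 (0.21 log units; within the scatter), and the step from compound 1 to compound 3 was a 1.2-fold lower number from compound 1 to compound 3 (0.07 log units; within the scatter).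

Compound 4, `O=C(NO)c1ccc(Cn2ccc3cc(C(=O)c4ccc(Cl)cc4)ccc32)cc1`, is the next member. It differs from compound 3 in one place: chloro in place of methoxy on an aromatic carbon. The closest comparison is the exchange of fluoro for methoxy between compound 2 and compound 3, which moved the number only within the scatter. A halogen in place of methoxy has therefore not produced a step beyond the scatter in this set, and no larger effect is expected for compound 4 in this assay; the estimate is a step of a 1.4-fold higher number from compound 3 to compound 4 (0.14 log units; within the scatter), which means compound 4 is expected to give about 900 nM, within a range from 400 nM to 2000 nM.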

Compound 4, half-maximal inhibitory concentration: 1060 nM
Compound 4: middle estimate off by 1.2-fold (0.07 log units), on the low side, within the range that was stated.
By their numbers in this assay, from the lowest: compounds 3, 1, 4 and 2 (each within the scatter of the next).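

With chloro, a second halogen has now been placed on the ring attached to the carbonyl, and in this assay the exchange of methoxy for chloro gives a 1.6-fold higher number from compound 3 to compound 4 (0.22 log units; within the scatter) and so stays within the scatter, as the exchange of fluoro for methoxy did. The two halogens cannot be told apart here, with a 1.2-fold lower number from compound 2 to compound 4 (0.07 log units; within the scatter) for chloro in place of fluoro, and the 4-chlorophenyl group cannot be told apart from the 3,4-dimethoxyphenyl group either, with a 1.4-fold higher number from compound 1 to compound 4 (0.15 log units; within the scatter) for that exchange, so all four ring variants shown remain within the scatter of one another. The data shown include no separate evidence that could explain why these groups read alike.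

On these data alone, the groups at this place are limited to methoxy, fluoro and chloro, so it remains open whether an amine, a carboxylic acid or a longer chain such as butoxy would give a step beyond the scatter. All four compounds also keep the same core and the same hydroxamic acid, which leaves open how far this flat picture holds on any other core or with any other group in place of the hydroxamic acid.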